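The source may report more compounds than this note shows. Statements on the series, on what has been measured and on what is new or still open speak of the compounds shown alone.

Of the compounds shown here, three built on one shared core have been measured in a functional assay on B16-F0 cells (Mus musculus) for inhibition, read by CCK-8 assay, with a stated time of 48 h; a lower number here means a stronger inhibitor, a higher number a weaker inhibitor. Compound 1 `C=Cc1ccc(-c2cc3nccc(-c4cc(OC)c(OC)c(OC)c4)n3n2)cc1` gives 788 nM, and compound 2 `COc1cc(-c2ccnc3cc(-c4ccc5ccn(C)c5c4)nn23)cc(OC)c1OC` gives 657 nM. Between these two lies a 1.2-fold lower number from compound 1 to compound 2 (0.08 log units; within the scatter). Compound 3 `COc1ccc(-c2cc3nccc(-c4cc(OC)c(OC)c(OC)c4)n3n2)cc1F` gives 3950 nM, the highest number of the three, which makes it the weakest inhibitor of the set. Its gap to the others is clear: a 5.0-fold higher number from compound 1 to compound 3 (0.70 log units; beyond the scatter) and a 6.0-fold higher number from compound 2 to compound 3 (0.78 log units; beyond the scatter).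

The next compound, compound 4 `COc1ccc(-c2cc3nccc(-c4cc(OC)c(OC)c(OC)c4)n3n2)cc1[N+](=O)[O-]`, differs from compound 3 in a single substituent: nitro in place of fluoro on an aromatic carbon, ortho to a methoxy group (nitro in place of fluoro on an aromatic carbon). Going by the values given here, no measured compound carries a nitro group, and no measured step touches the fluoro alone, so the evidence is indirect. The two steps from compound 1 and compound 2 swap a whole group at this site, and they offer an upper guide to the size of change in this assay. A smaller move is expected from one substituent. Compound 3 already sits highest at 3950 nM, so a slight lean toward a lower number is expected. The expected change is a 1.6-fold lower number from compound 3 to compound 4 (0.20 log units; within the scatter). The estimated value for compound 4 is 2500 nM, with an expected range from 700 nM to 9000 nM.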

Compound 4, half-maximal inhibitory concentration: > 10000 nM
Compound 4 was reported as a limit (the forecaster's own chance of this, stated with the estimate: 5%); middle value at least 4.0-fold (0.60 log units) from the limit.
By their numbers in this assay, from the lowest: compounds 2 and 1 (each within the scatter of the next); then compound 3. At a limit, above all of these: compound 4.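

Until now, every step at this end of the molecule swapped a whole aromatic group, so the effect of one small substituent on that ring could not be seen apart from the rest. Compounds 3 and 4 keep the methoxy group and the rest of the structure the same, and they show that a single substituent change can matter on its own in this assay: putting nitro in place of fluoro, ortho to a methoxy group, gives an at least 2.5-fold higher number from compound 3 to compound 4 (0.40 log units; beyond the scatter). Compound 4 is recorded as > 10000 nM, which is a limit of the assay and not a number, so the step has a floor but no known full size: the limit of > 10000 nM in this assay, at which 1 of the 4 values shown sits.

With only fluoro and nitro shown at this place, a single pair cannot tell whether the weaker result is particular to nitro or would follow from other substituents there too. An amine, a nitrile or a plain hydrogen at the same place, with the methoxy group kept, would begin to separate these possibilities.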